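This account rests on a few compounds, and the source may have more. Where it says the series, first, only, none or still open, it means among the compounds named here.

In a functional assay on HeLa cells (Homo sapiens) for inhibition, read by CCK-8 assay, with a stated time of 72 h (on this read-out lower numbers stand for stronger inhibition and higher numbers for weaker inhibition), compound 1 `Cc1ccc(NS(=O)(=O)c2cccc(CCCCCCNC(=O)/C=C/c3cccnc3)c2)cc1` gives 38.8 nM and compound 2 `CCc1ccc(NS(=O)(=O)c2cccc(CCCCCCNC(=O)/C=C/c3cccnc3)c2)cc1` gives 132 nM, while compound 3 `CC(C)(C)c1ccc(NS(=O)(=O)c2cccc(CCCCCCNC(=O)/C=C/c3cccnc3)c2)cc1` gives 1520 nM as the highest number of the three, which makes it the weakest inhibitor so far. Compound 4 `O=C(/C=C/c1cccnc1)NCCCCCCc1cccc(S(=O)(=O)Nc2ccc(F)c(Cl)c2)c1` has not yet been measured. It differs from compound 3 at one place, with 3-chloro-4-fluorophenyl in place of 4-(tert-butyl)phenyl on a sulfonamide nitrogen. The measured steps that bear on this all alter that same group. The step of a 39-fold higher number from compound 1 to compound 3 (1.59 log units; beyond the scatter) is large, the step of a 12-fold higher number from compound 2 to compound 3 (1.06 log units; beyond the scatter) is also large, and the step of a 3.4-fold higher number from compound 1 to compound 2 (0.53 log units; beyond the scatter) is modest. Among the measured compounds shown here, none of the measured compounds carries chlorine or fluorine, so that part of the change is untested. Leaving the tert-butyl compound has so far always meant a lower number, so a large step downward is expected in this assay. The estimate amounts to a 19-fold lower number from compound 3 to compound 4 (1.28 log units; beyond the scatter) as the expected change. For compound 4 the estimated value is 80 nM with an expected range from 20 nM to 350 nM for repeated measurements.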

Compound 4, half-maximal inhibitory concentration: 385 nM
Compound 4: middle estimate off by 4.8-fold (0.68 log units), on the low side, outside the stated range (above it).
By their numbers in this assay, from the lowest: compound 1; then compound 2; then compound 4; then compound 3.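

In this assay, 3-chloro-4-fluorophenyl in place of 4-(tert-butyl)phenyl on the sulfonamide nitrogen gives a 3.9-fold lower number from compound 3 to compound 4 (0.60 log units; beyond the scatter) as a modest gain, the first view of a ring carrying halogens at this position. The same ring still falls short of the two compounds with smaller alkyl groups, with a 2.9-fold higher number from compound 2 to compound 4 (0.46 log units; beyond the scatter) and a 9.9-fold higher number from compound 1 to compound 4 (1.00 log units; beyond the scatter), so moving away from tert-butyl does not by itself restore the low numbers of the 4-methylphenyl and 4-ethylphenyl compounds. No measurement available here explains these differences.

Because chlorine and fluorine arrive together, the compounds shown leave open what each contributes alone. Also open, going by these compounds, is how an unsubstituted phenyl, a 4-methoxyphenyl or a pyridine ring would read on this nitrogen.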